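Bromophenyl for Methoxyphenylamino Against a Cytotoxicity Limit

The source may report more compounds than this note shows. Statements on the series, on what has been measured and on what is new or still open speak of the compounds shown alone.

Compound 1, `C=C[C@@](C)(/C=C/c1ccc(Nc2ccc(OC)cc2)cc1)CCC=C(C)C`, was tested in a functional assay on HepG2 cells (Homo sapiens) for cytotoxicity, with a stated time of 72 h; on this read-out higher numbers stand for an effect only at larger amounts of compound and lower numbers for an effect already at smaller amounts. In this assay compound 1 gives > 52000 nM, which is a limit of the assay and not a number. Two close relatives stand the same way. Compound 2, `C=C[C@@](C)(/C=C/c1ccc(Nc2c(F)cc(F)cc2F)cc1)CCC=C(C)C`, gives > 52000 nM in this assay, again only a limit. Compound 3, `C=C[C@@](C)(/C=C/c1ccc(Nc2ccc(C(F)(F)F)cc2)cc1)CCC=C(C)C`, gives > 52000 nM in this assay, once more a limit. The steps a step that the two limits leave unreadable from compound 1 to compound 2 and a step that the two limits leave unreadable from compound 1 to compound 3 cannot be sized, a direct consequence of the limit of > 52000 nM in this assay, at which 3 of the 3 values shown sit. Neither exchange on the nitrogen-linked ring produced a readable value, so no direction of change can be drawn from them.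

The unmeasured compound 4, `C=C[C@@](C)(/C=C/c1ccc(-c2cccc(Br)c2)cc1)CCC=C(C)C`, differs from compound 1 by 3-bromophenyl in place of (4-methoxyphenyl)amino on an aromatic carbon. Since all measured steps around compound 1 remained unreadable at the limit, no step beyond the scatter in this assay is expected for this change either. Compound 4 is estimated to give about 60000 nM in this assay. The range for compound 4 is expected to span from 20000 nM to 200000 nM. The expected step that the limit leaves unreadable from compound 1 to compound 4 is thus essentially none, and compound 4 is expected most likely to return only a limit as well.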

Compound 4, half-maximal effective concentration: > 52000 nM
Compound 4: a limit, no number; the forecaster's own chance of this, stated with the estimate: 75%; the middle value does not contradict the limit.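

In this assay compound 4 gives > 52000 nM as a limit and not a number. For the compounds shown here, no step from compound 1 to compound 4 can be read: the limit of > 52000 nM in this assay, at which 4 of the 4 values shown sit. The compounds shown leave open which change to the shared core, if any, would give a readable value.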